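The compounds below may be only part of what the source reports. "The series", "measured", "known", "first", "only" and "open" are said of these compounds alone.

Compound 1 `Nc1nc2cc(-c3nn(CCCCCCCCCC(=O)NO)c4ncnc(N)c34)ccc2o1` gives in a functional assay on HeLa cells (Homo sapiens) for inhibition, read by MTT assay, with a stated time of 72 h (on this read-out higher numbers stand for weaker inhibition and lower numbers for stronger inhibition), only a limit, > 50000 nM. Compound 2 `Nc1ncnc2c1c(-c1cnc3[nH]ccc3c1)nn2CCCCCCCCCC(=O)NO` gives 7560 nM. Compound 3 `Nc1nc2cc(-c3nn(CCCCCCCCC(=O)NO)c4ncnc(N)c34)ccc2o1` gives 10200 nM, and the values of compound 2 and compound 3 lie within the usual scatter of each other, so neither is set apart. The third value shown, that of compound 1, is the limit (the limit of > 50000 nM in this assay, at which 1 of the 3 values shown sits). The two measured steps both start from that limit: an at least 6.6-fold lower number from compound 1 to compound 2 (0.82 log units; beyond the scatter), and an at least 4.9-fold lower number from compound 1 to compound 3 (0.69 log units; beyond the scatter).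

Compound 4 `Nc1ncnc2c1c(-c1cnc3[nH]ccc3c1)nn2CCCCC(=O)NO` differs from compound 2 by hydroxycarbamoyl in place of 5-(hydroxycarbamoyl)pentyl on a saturated chain carbon, four bonds along the chain from an aromatic nitrogen. Among the measured compounds shown here, the only measured step of the same kind, an at least 4.9-fold lower number from compound 1 to compound 3 (0.69 log units; beyond the scatter), removes a single chain carbon and starts from a limit, so it fixes no size for a change that removes five. For the measured compounds named here, no measured compound carries so short a chain. He therefore expects a step beyond the scatter toward weaker inhibition, a 2.4-fold higher number from compound 2 to compound 4 (0.38 log units; beyond the scatter), with wide uncertainty. His estimate for compound 4 in this assay is 18000 nM, between 5000 nM and 50000 nM.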

Compound 4, half-maximal inhibitory concentration: > 150000 nM
Compound 4 gave a limit, no number (the forecaster's own chance of this, stated with the estimate: 20%); middle value at least 8.3-fold (0.92 log units) away from the limit.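

In this assay, among the compounds shown here, shortening the chain on the core of compound 2 gives an at least 19-fold higher number from compound 2 to compound 4 (1.29 log units; beyond the scatter), the first step here that starts from a measured number, and it shows that inhibition on this core does not survive this cut in the chain. The size of that step is only a lower bound, since compound 4 gives a limit and not a number: the limit of > 150000 nM in this assay, at which 1 of the 4 values shown sits.

For the compounds shown here, the one other chain step, an at least 4.9-fold lower number from compound 1 to compound 3 (0.69 log units; beyond the scatter), runs the opposite way on a different aromatic group, so shortening the chain has no single direction across these compounds.

The compounds shown leave open where along the chain, from 5-(hydroxycarbamoyl)pentyl down to hydroxycarbamoyl, the inhibition falls away. They also leave open how a longer chain, or a carboxylic acid at the chain end, would read on this core.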